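Swapping the benzoyl fluorines for a trifluoromethyl group

A few compounds are considered here, and "the series" means these few. Any claim that something is new, unique, unknown or untested is made for them only; others in the source may bear on it.

Measured compounds:
- compound 1, `CN(C(=O)NC(=O)c1ccc(F)c(F)c1)c1nc(C(F)(F)F)c(C(=O)N/N=C/c2ccc(C(F)(F)F)cc2)s1`: 3.85 ug/mL
- compound 2, `CNc1nc(C)c(C(=O)N/N=C/c2ccccc2C(F)(F)F)s1`: > 100 ug/mL

Among the compounds with values here, in a functional assay on BCG823 cells (Homo sapiens) for inhibition, read by MTT assay, with a stated time of 72 h (on this read-out higher numbers stand for weaker inhibition and lower numbers for stronger inhibition), compound 1 gives 3.85 ug/mL, the only number obtained. For compound 2 this assay reports only a limit, > 100 ug/mL, as recorded under (the limit of > 100 ug/mL in this assay, at which 1 of the 2 values shown sits). The two differ in several places at once, so no single step can be read between them; what is shown is simply that compound 1 yields a number while compound 2 does not.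

Compound 3, `CN(C(=O)NC(=O)c1cccc(C(F)(F)F)c1)c1nc(C(F)(F)F)c(C(=O)N/N=C/c2ccc(C(F)(F)F)cc2)s1`, has not yet been measured. It keeps the core of compound 1 and changes one group: 3-(trifluoromethyl)phenyl in place of 3,4-difluorophenyl on a carbonyl carbon. Both groups carry no hydrogen-bond donors or acceptors and no net charge, and the aromatic ring stays a six-membered ring of carbon only.

Within the data shown here, with no measured step of this kind available, the author expects compound 3 to sit close to compound 1, with the step of a 1.1-fold lower number from compound 1 to compound 3 (0.04 log units; within the scatter) not reaching beyond the usual scatter. For compound 3 the estimate in this assay is 3.5 ug/mL, with a range from 1.2 ug/mL to 10 ug/mL.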

Compound 3, half-maximal inhibitory concentration: 4.22 ug/mL
Beside the measured number, compound 3's estimate is 1.2-fold (0.08 log units) below it; the range from low to high includes it.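

In this assay, within the data shown here, 3-(trifluoromethyl)phenyl in place of 3,4-difluorophenyl on a carbonyl carbon gives a 1.1-fold higher number from compound 1 to compound 3 (0.04 log units; within the scatter) and is the first single change that can be read. The position therefore takes either of these two substituted phenyl groups without a measurable shift, even though the group that enters has 10 heavy atoms where the one that leaves has 8. No measurement shown bears on why the two groups read alike.

The compounds shown leave open whether a group of another kind on that carbonyl carbon, such as a phenyl ring carrying an amine or a carboxylic acid, or a plain methyl group, would keep the number in the same range. Among these compounds, for compound 2, which differs from the others in several places at once, this assay gives only the limit > 100 ug/mL and no step to it can be read.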